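Cytotoxicity Limits and a Methylsulfonyl Replacement

This account rests on a few compounds, and the source may have more. Where it says the series, first, only, none or still open, it means among the compounds named here.

Compound 1 `CCOC(=O)c1cnc(N2CCN(Cc3ccc(F)cc3)CC2)nc1Oc1c(C)cc(-c2ccc(C#N)cc2)cc1C` and compound 2 `CCOC(=O)c1cnc(N2CCN(Cc3ccccc3Br)CC2)nc1Oc1c(C)cc(-c2ccc(C#N)cc2)cc1C` are separated by a step that the two limits leave unreadable from compound 1 to compound 2. In an ADME assay on MT4 cells (Homo sapiens) for cytotoxicity, read by MTT assay, with a stated time of 4 days (on this read-out higher numbers stand for lower toxicity in this test and lower numbers for higher toxicity in this test), compound 1 reaches only the limit > 117000 nM. Compound 2 in this assay likewise stops at the limit > 125000 nM. Compound 2 thus sits at the edge of what this assay reports (the limit of > 125000 nM in this assay, at which 1 of the 2 values shown sits). Compound 3 `CCOC(=O)c1cnc(N2CCN(Cc3ccc(S(C)(=O)=O)cc3)CC2)nc1Oc1c(C)cc(-c2ccc(C#N)cc2)cc1C` carries 4-(methylsulfonyl)phenyl in place of 2-bromophenyl on a saturated chain carbon bound to an amine nitrogen in a ring. Going by the values given here, the single measured step is unreadable, so the expected step of a number no higher from compound 2 to compound 3 (the limit leaves the size open) is none beyond the scatter. Compound 3 is therefore estimated at 125000 nM, between 60000 nM and 260000 nM, most probably again reported only as a limit.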

Compound 3, half-maximal cytotoxic concentration: > 125000 nM
Compound 3: a limit, no number; the forecaster's own chance of this, stated with the estimate: 80%; the middle value sits exactly at the limit.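

Going by these compounds alone, compound 1, compound 2 and compound 3 all stop at limits in this assay, so no step among them can be read. The compounds shown leave open whether the groups exchanged on the shared core change cytotoxicity at all.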